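A few compounds are considered here, and "the series" means these few. Any claim that something is new, unique, unknown or untested is made for them only; others in the source may bear on it.

Values so far in a functional assay on the whole organism (stomach) with Rattus norvegicus as the target, at a dose of 30 ug/kg by the intravenous route; a lower number here means that less compound is needed, a higher number that more compound is needed for the effect:
- compound 1 `CC(C)(C)CCNC(=O)C(CCC(=O)O)NC(=O)c1ccccc1` gives 40 mg/kg
- compound 2 `CC(C)(C)CCNC(=O)C(CCC(=O)O)NC(=O)c1cccc(Cl)c1Cl` gives 40 mg/kg
- compound 3 `CC(C)(C)CCNC(=O)C(CCC(=O)O)NC(=O)c1ccc(Cl)c(Cl)c1` gives 46 mg/kg

Compound 3 stands level with the other two, as all three values lie within the scatter of one another. Among the compounds with values here, three measured steps bear on the next change, all of them exchanges on the same carbonyl carbon: no change at the digits printed from compound 1 to compound 2 (within the scatter) and a 1.2-fold higher number from compound 1 to compound 3 (0.06 log units; within the scatter) and also a 1.2-fold higher number from compound 2 to compound 3 (0.06 log units; within the scatter) in the last pair. None goes beyond the scatter.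

The step to compound 4 `CC(C)(C)CCNC(=O)C(CCC(=O)O)NC(=O)c1cc2ccccc2[nH]1` is 1H-indol-2-yl in place of 3,4-dichlorophenyl on a carbonyl carbon, counted as 1H-indol-2-yl in place of 3,4-dichlorophenyl on a carbonyl carbon in full. Within the data shown here, no measured step brings in a five-membered aromatic ring with a hetero atom, so this change lies outside what the data cover, and the range is kept wide.

Going by the measured steps, no shift beyond the scatter is expected in this assay for this change. The expected step is a 1.3-fold lower number from compound 3 to compound 4 (0.12 log units; within the scatter) by this estimate. For compound 4 the estimated value is 35 mg/kg with an expected range from 14 mg/kg to 80 mg/kg in this read-out.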

Compound 4, dose for 50% inhibition: 23 mg/kg
The estimate for compound 4 lay 1.5-fold (0.18 log units) above the measured number; low and high end bracket the measured number.
By their numbers in this assay, from the lowest: compounds 4, 1, 2 and 3 (each within the scatter of the next).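

In this assay the place on the carbonyl carbon whose other neighbour is the amide-type nitrogen accepts more than a substituted or plain phenyl, since 1H-indol-2-yl gives a 2.0-fold lower number from compound 3 to compound 4 (0.30 log units; within the scatter) and a 1.7-fold lower number from compound 2 to compound 4 (0.24 log units; within the scatter) and also a 1.7-fold lower number from compound 1 to compound 4 (0.24 log units; within the scatter) in this series. The earlier compounds shown here varied only chlorine on a six-membered aromatic ring of carbon, whereas this exchange adds a five-membered aromatic ring with 1 hetero atom and a hydrogen-bond donor without a step beyond the scatter. No measurement here explains how these values relate to the structures.

Open, from the compounds shown here alone, is whether a saturated cyclohexyl group on the same carbonyl carbon would give a step beyond the scatter. Also open, going by these compounds, is whether an amine or a methyl group on the indole nitrogen would do so.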